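Trimethoxyphenyl triazoles: a fluoro-to-chloro step

The source may report more compounds than this note shows. Statements on the series, on what has been measured and on what is new or still open speak of the compounds shown alone.

Measured compounds:
Compound 1 `COc1cc(-c2ncnn2-c2ccccc2)cc(OC)c1OC` gives > 10000 nM in a functional assay on A549 cells (Homo sapiens) for antiproliferative activity, read by MTT assay, with a stated time of 72 h; on this read-out higher numbers stand for weaker inhibition and lower numbers for stronger inhibition.
Compound 2 `COc1cc(-n2ncnc2-c2ccc(F)cc2)cc(OC)c1OC` gives > 10000 nM in this assay.
Compound 3 `COc1cc(-n2ncnc2-c2cccc(F)c2)cc(OC)c1OC` gives > 10000 nM in this assay.

Each of these values is a limit of this assay and not a number; all three sit at the limit of > 10000 nM in this assay, at which 3 of the 3 values shown sit. Compound 3 therefore stands only at a limit, with nothing in the set resolved into a number. Among the measured compounds shown here, the one single-point step measured, a step that the two limits leave unreadable from compound 2 to compound 3, is unreadable, as both ends are limits.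

Compound 4 `COc1cc(-n2ncnc2-c2cccc(Cl)c2)cc(OC)c1OC` has not been measured. It differs from compound 3 by chloro in place of fluoro on an aromatic carbon. For the measured compounds named here, no measured step bears on a chloro-for-fluoro exchange here, and the only step in the set, a step that the two limits leave unreadable from compound 2 to compound 3, gives no size, so no direction can be drawn from the data. Given that compound 3 sits at the limit > 10000 nM, compound 4 is expected most likely to return a limit as well, with an estimated step that the limit leaves unreadable from compound 3 to compound 4 that is not expected to exceed the scatter. Compound 4 is estimated at 15000 nM, with a range of 4000 nM to 60000 nM.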

Compound 4, half-maximal inhibitory concentration: > 10000 nM
Compound 4 was reported as a limit; the forecaster's own chance of this, stated with the estimate: 75%; the middle value is on the limit's open side.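

In this assay compound 4 gives > 10000 nM, a limit and not a number. No new step can be read from compound 2 or compound 3 to compound 4, as all values shown sit at one limit: the limit of > 10000 nM in this assay, at which 4 of the 4 values shown sit.

Left open is whether 3-chlorophenyl, 3-fluorophenyl and 4-fluorophenyl differ at all in this assay.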